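Nitro in place of hydrogen on the core of compound 2

The source may hold more compounds than are shown below. What is called first, only, known or untested is meant among the compounds shown, and "the series" means these compounds.

Measured so far in a functional assay on MCF7 cells (Homo sapiens) for cytotoxicity, read by MTT assay; a lower number here means a stronger inhibitor, a higher number a weaker inhibitor:
compound 1, `NS(=O)(=O)c1nnc(NCc2nc3ccccc3[nH]2)s1`, gives 228000 nM
compound 2, `Fc1ccc2nc(NCc3nc4ccccc4[nH]3)sc2c1`, gives 242000 nM
compound 3, `O=[N+]([O-])c1ccc2[nH]c(CN3CCN(c4ccc(F)cc4)CC3)nc2c1`, gives 15000 nM

Compound 2 has the highest number of the three, though its value and that of compound 1 lie within the usual scatter of each other, so no order between those two can be read. Compound 3 sits well apart: its number is lower than that of compound 2 by a gap that lies beyond the scatter. Compound 3 differs from compound 2 in several places at once, so its lower number cannot be tied to any single change.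

Compound 4, `O=[N+]([O-])c1ccc2[nH]c(CNc3nc4ccc(F)cc4s3)nc2c1`, is not yet measured. It differs from compound 2 by one change: nitro in place of hydrogen on an aromatic carbon. Among the compounds with values here, compound 3, the one compound with a lower number, also carries a nitro group, but nothing else in the data isolates this change, so the expectation rests on weak ground. A modest step toward a lower number in this assay is expected for compound 4, though one no larger than the scatter would not surprise. For compound 4 a value of 110000 nM is estimated, between 30000 nM and 300000 nM, which would mean an expected step of a 2.2-fold lower number from compound 2 to compound 4 (0.34 log units; beyond the scatter).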

Compound 4, half-maximal inhibitory concentration: 291000 nM
The estimate for compound 4 lay 2.6-fold (0.42 log units) below the measured number; measured number inside the range.
By their numbers in this assay, from the lowest: compound 3; then compounds 1, 2 and 4 (each within the scatter of the next).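

In this assay, the nitro group placed on an aromatic carbon of the six-membered aromatic ring of carbon only, on the side of compound 2 that has no fluorine, gives a 1.2-fold higher number from compound 2 to compound 4 (0.08 log units; within the scatter) and so leaves the number of the parent within the usual scatter. Within the data shown here, this is the first isolated reading of the change, and it shows that at this place, with this amino-linked side of the molecule held fixed, nitro in place of hydrogen brings no gain that can be told from repeated measurement. The nitro group shared with compound 3, which gives 15000 nM, therefore cannot be taken on its own as the source of that lower number, and nothing in the data offers an explanation for the flat step.

No partner of compound 3 with hydrogen in place of its nitro group is shown. As far as these compounds go, whether that group has any part in the number of compound 3 stays open. Equally open, from the compounds shown here alone, is whether an amine or a carboxylic acid in place of the nitro group, on the same carbon, would move the number beyond the scatter.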